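Phenyl for Cyclopropyl on the Acyl Group of Compound 3

The source may hold more compounds than are shown below. What is called first, only, known or untested is meant among the compounds shown, and "the series" means these compounds.

Compound 1 `Cc1cccc(-c2c(N)n[nH]c2C)c1`: in an assay on Sf9 cells for inhibition of mitogen-activated protein kinase kinase kinase 14 (Homo sapiens), read by ADP-Glo, with a stated time of 60 min (a lower number here means a stronger inhibitor, a higher number a weaker inhibitor), compound 1 gives > 100000 nM, which is a limit of the assay.
Compound 2 `Cc1[nH]nc(N)c1-c1cccc(Cl)c1`: in this assay compound 2 gives > 100000 nM, again a limit of the assay.
Compound 3 `Cc1nn(C(=O)C2CC2)c(N)c1-c1ccc(Cl)c(Cl)c1`: in this assay compound 3 gives 24300 nM.

For the measured compounds named here, compound 3 thus holds the only number among the three, the other two resting at the limit of > 100000 nM in this assay, at which 2 of the 3 values shown sit. The step that the two limits leave unreadable from compound 1 to compound 2 cannot be read from those limits. Compound 4 `Cc1nn(C(=O)c2ccccc2)c(N)c1-c1ccc(Cl)c(Cl)c1` differs from compound 3 by phenyl in place of cyclopropyl on a carbonyl carbon. Going by the values given here, no measured step alters that acyl group, so none of them bears on this change. Compound 4 is therefore expected to show a 1.6-fold lower number from compound 3 to compound 4 (0.21 log units; within the scatter), not beyond the scatter, and its estimated value in this assay is 15000 nM, from 3000 nM to 70000 nM.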

Compound 4, half-maximal inhibitory concentration: 23000 nM
The estimate for compound 4 lay 1.5-fold (0.19 log units) below the measured number, and the stated range covers the measured number.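

On the carbonyl carbon, phenyl in place of cyclopropyl gives a 1.1-fold lower number from compound 3 to compound 4 (0.02 log units; within the scatter) in this assay, and this is the first readable step among the compounds shown. The position therefore accepts a six-membered aromatic ring in place of a three-membered non-aromatic ring without a change in the number beyond the scatter. Nothing measured here accounts for this result.

The compounds shown leave open whether an amine, a carboxylic acid or a longer chain on that carbonyl carbon would move the number beyond the scatter. They also leave open what a methoxy group on the phenyl would do.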